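A few compounds are considered here, and "the series" means these few. Any claim that something is new, unique, unknown or untested is made for them only; others in the source may bear on it.

Measured so far:
Compound 1 `CCOc1cccc(-c2ccc(CN(C(=O)C3CCCCC3)c3cccc(/C=C/C(=O)OC)c3)cc2)c1`: in an assay on isolated protein with Bile acid receptor (Homo sapiens) as the target (a higher number here means that more compound is needed for the effect, a lower number that less compound is needed), compound 1 gives 147 nM.
Compound 2 `CCOc1cccc(-c2ccc(CN(C(=O)C(C)C)c3cccc(/C=C/C(=O)OC)c3)cc2)c1`: compound 2 gives 173 nM.
Compound 3 `COC(=O)/C=C/c1cccc(N(Cc2ccc(/C=C/C(=O)OC(C)(C)C)cc2OCc2ccccc2)C(=O)C2CCCCC2)c1`: for compound 3 the assay reports only a limit, > 1000 nM.

Compound 1 holds the lowest of the two numbers, but its nearest neighbour, compound 2, sits within the usual scatter of repeated measurements, so the two cannot be told apart. For the measured compounds named here, the only step between two measured compounds, a 1.2-fold higher number from compound 1 to compound 2 (0.07 log units; within the scatter), changes the group on the carbonyl carbon and leaves the rest of the molecule untouched. Going by the values given here, compound 3, whose value is a limit, differs from the others at several places at once and so provides no single step.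

The unmeasured compound 4 `COC(=O)/C=C/c1cccc(N(Cc2ccc(-c3ccc(SC)cc3)cc2)C(=O)C2CCCCC2)c1` differs from compound 1 in one place: 4-(methylsulfanyl)phenyl in place of 3-ethoxyphenyl on an aromatic carbon. Among the compounds with values here, no measured step touches this part of the molecule, so nothing here fixes the size of the step; the one step that was measured was small. The expectation is therefore a step close to no change, a 1.5-fold higher number from compound 1 to compound 4 (0.18 log units; within the scatter). Compound 4 is estimated at 220 nM, with a range from 90 nM to 600 nM.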

Compound 4, half-maximal effective concentration: 69 nM
Estimate against measurement, compound 4: 3.2-fold (0.50 log units) above; measured number below the stated range.
By their numbers in this assay, from the lowest: compound 4; then compounds 1 and 2 (each within the scatter of the next). At a limit, above all of these: compound 3.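

In this assay, putting 4-(methylsulfanyl)phenyl in place of 3-ethoxyphenyl on an aromatic carbon gives a 2.1-fold lower number from compound 1 to compound 4 (0.33 log units; beyond the scatter) and is the first step among these compounds to go beyond the scatter, though only modestly. The earlier step, at the carbonyl carbon, gave a 1.2-fold higher number from compound 1 to compound 2 (0.07 log units; within the scatter) and so showed no readable change, whereas this second place in the molecule does respond to a change of group. The swap keeps one six-membered aromatic ring of carbon only and nearly the same number of heavy atoms, yet nothing measured here explains why the number falls.

The swap changes both the atom that links the small group to the ring, oxygen to sulfur, and the group's place on that ring, and the compounds shown do not separate these two changes. They also leave open how a phenyl ring carrying an amine or a carboxylic acid would behave at this place, and whether isopropyl on the carbonyl carbon would still match cyclohexyl alongside 4-(methylsulfanyl)phenyl.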